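From Iodo to Chloro on a Growth Inhibitor

The source may report more compounds than this note shows. Statements on the series, on what has been measured and on what is new or still open speak of the compounds shown alone.

Among the measured compounds shown here, in a functional assay on HCC 2998 cells (Homo sapiens) for inhibition (on this read-out higher numbers stand for weaker inhibition of growth and lower numbers for stronger inhibition of growth), compound 1 (`Nc1ccc(-c2nc3ccc(F)cc3s2)cc1I`) gives 320 nM, the only actual number so far. Compound 2 (`Cc1cc(-c2nc3c(F)cccc3s2)ccc1N`) reads > 100000 nM, which is a limit of the assay. Compound 3 (`Nc1ccc(-c2nc3ccc(F)cc3s2)cc1Cl`) differs from compound 1 as follows: chloro in place of iodo on an aromatic carbon. This puts chloro in place of iodo on an aromatic carbon, ortho to an amino group. For the measured compounds named here, no two measured compounds differ in one place alone, so nothing here sizes this swap directly. The expectation in this assay is therefore no step beyond the scatter, in either direction. The expected change is a 1.1-fold lower number from compound 1 to compound 3 (0.03 log units; within the scatter). Compound 3 is estimated at 300 nM, with a range of 60 nM to 2000 nM.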

Compound 3, concentration for 50% growth inhibition: 90 nM
Beside the measured number, compound 3's estimate is 3.3-fold (0.52 log units) above it, and the stated range covers the measured number.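

Among the compounds shown here, compound 1 and compound 3 form the first pair here that differs in one place alone, so the effect of a change at this position can now be read directly. Putting chloro in place of iodo on this aromatic carbon, ortho to an amino group, gives a 3.6-fold lower number from compound 1 to compound 3 (0.55 log units; beyond the scatter) in this assay, meaning stronger inhibition of growth, so this position is sensitive to which halogen it carries. Nothing given here explains why chloro outperforms iodo.

Whether bromo, which is absent from the compounds shown, or a methoxy group would do better or worse at this position remains open. So does whether this step would keep its size on a different core.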